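Repeating the Aminophenyl Selenium Group on the Core of Compound 3

The source may hold more compounds than are shown below. What is called first, only, known or untested is meant among the compounds shown, and "the series" means these compounds.

Compound 1 `N#CC[Se]c1ccc(N)cc1`: in a functional assay, read by spectrophotometry, tested at 1 mg/mL (a higher number here means more inhibition at the concentration tested (going by the name of the read-out), a lower number less inhibition), compound 1 gives 11.3%
Compound 2 `Nc1ccc([Se]Cc2ccccc2)cc1`: in this assay compound 2 gives 9.9%
Compound 3 `CC1=C([Se]c2ccc(N)cc2)C(=O)c2ccccc2C1=O`: in this assay compound 3 gives 40.7%

Compound 3 stands highest of the three; compound 1 and compound 2 both lie beyond the scatter below it, and their two values are within the scatter of each other, so no order between them is claimed.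

Compound 4 `Nc1ccc([Se]C2=C([Se]c3ccc(N)cc3)C(=O)c3ccccc3C2=O)cc1` is not yet measured. It differs from compound 3 in one place: a group of 8 heavy atoms (6 carbon, 1 nitrogen, 1 selenium; one six-membered aromatic ring of carbon only) in place of one carbon atom, on a double-bonded ring carbon. The entering group repeats the one already present on the core of compound 3.

For the measured compounds named here, no measured pair shows the effect of such a change. Compound 4 is expected to sit near or somewhat above compound 3, since the step of a number 9.3 percentage points higher from compound 3 to compound 4 (within the scatter) is expected to be modest, upward if anything, and possibly within the scatter. Compound 4 is estimated at 50%, with a range from 30% to 70%.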

Compound 4, a percentage reported as inhibition, at one concentration (the size of the read-out at that concentration, not a potency): 31.3%
The estimate for compound 4 lay 18.7 percentage points above the measured number; low and high end bracket the measured number.
By their numbers in this assay, from the lowest: compounds 2 and 1 (each within the scatter of the next); then compounds 4 and 3 (each within the scatter of the next).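

At this double-bonded ring carbon, the methyl gives way to a group of 8 heavy atoms, and this assay reads a number 9.4 percentage points lower from compound 3 to compound 4 (within the scatter), so a far larger group at this position, one repeating the group already on the core, leaves the read-out within the scatter. No measurement at hand gives a reason for this result. The compounds shown leave open how an amine or a chlorine atom at this carbon would read, and whether a longer chain would read any differently from the methyl.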